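Swapping a Butyl Chain for a Cyclopentyl Ring: Expected Loss

The source may report more compounds than this note shows. Statements on the series, on what has been measured and on what is new or still open speak of the compounds shown alone.

Three measured compounds share a core built around a fused two-ring system carrying a ring nitrogen that bears a small carbon group. Compound 1 `CCCCn1cnc2c(Nc3ccccc3)nc(NCOCc3ccc(/C=C/C(=O)Nc4ccccc4N)cc3)nc21` gives 51.9% in a functional assay on HCT-116 cells (Homo sapiens) for antiproliferative activity, read by CCK-8 assay, with a stated time of 72 h, tested at 8 uM; a higher number here means a stronger effect of the compound at the concentration tested, a lower number a weaker effect. Compound 2 `CCCCn1cnc2c(Nc3cccc(Cl)c3)nc(NCOCc3ccc(C(=O)Nc4ccccc4N)cc3)nc21` gives 71.9% in this assay; the difference between the cores of compound 1 and compound 2 is not broken down here. Compound 3 `Nc1ccccc1NC(=O)c1ccc(COCNc2nc(Nc3cccc(Cl)c3)c3ncn(C4CCCC4)c3n2)cc1` gives 40.6% in this assay. Compound 3 differs from compound 2 in one place only, (cyclopentyl in place of butyl on an aromatic nitrogen), and that single change produced the step of a number 31.3 percentage points lower from compound 2 to compound 3 (beyond the scatter).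

Compound 4 `Nc1ccccc1NC(=O)/C=C/c1ccc(COCNc2nc(Nc3ccccc3)c3ncn(C4CCCC4)c3n2)cc1` has not yet been measured in this assay. It differs from compound 1 by cyclopentyl in place of butyl on an aromatic nitrogen, the same change at the same place as seen between compound 2 and compound 3. A drop of comparable size is expected from compound 1 to compound 4, namely a number 24.9 percentage points lower from compound 1 to compound 4 (beyond the scatter), because a number 31.3 percentage points lower from compound 2 to compound 3 (beyond the scatter) arose from exactly this change and the two starting points differ only elsewhere. With a single earlier example to rest on, the range is kept wide. Compound 4 is therefore expected to give 27%, with a likely span from 10% to 45%.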

Compound 4, a percentage reported as inhibition, at one concentration (the size of the read-out at that concentration, not a potency): 17.3%
The estimate for compound 4 lay 9.7 percentage points above the measured number; measured number inside the range.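

Within this assay the new pair gives a number 34.6 percentage points lower from compound 1 to compound 4 (beyond the scatter) on going from butyl to cyclopentyl on an aromatic nitrogen. Set beside the earlier pair, the two losses agree in size: the same change on two cores in this assay, a number 31.3 percentage points lower (beyond the scatter) from compound 2 to compound 3 and a number 34.6 percentage points lower (beyond the scatter) from compound 1 to compound 4, 3.3 percentage points apart, within the scatter of two such steps. On these two cores, then, the change carried over with much the same large loss even though the cores differ elsewhere, but two pairs cannot show that this would hold on any other core in the series, and they say nothing about why the number falls.

The compounds shown carry only butyl or cyclopentyl on that ring nitrogen, so it remains open how a shorter chain such as ethyl, a longer chain such as hexyl, a cyclohexyl ring or a benzyl group would behave there. From the compounds shown here alone, it is equally open whether an amine or a carboxylic acid on such a chain would bring the number back towards those of the butyl compounds.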